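The compounds below may be only part of what the source reports. "The series", "measured", "known", "first", "only" and "open" are said of these compounds alone.

Working notes on the series. Two compounds have been run in a functional assay on MT2 cells (Homo sapiens) for cytotoxicity, read by MTT assay (a lower number here means that less compound is tolerated, a higher number that more compound is tolerated), so far. Compound 1 `Clc1ccc(Nc2nccs2)cc1OCC1=CCCC1` gives 15000 nM in this assay. Compound 2 `CC(C)=CCOc1cc(Nc2ncccn2)ccc1Cl` gives 2500 nM in this assay, the lower of the two numbers; the gap to compound 1 lies beyond the scatter, so compound 2 is the less tolerated of the pair. Among the measured compounds shown here, no pair of measured compounds differs in a single place, so no step between them can be isolated, and the two cores differ in more than one position at once.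

Compound 3 `COCc1ccnc(Nc2ccc(Cl)c(OCC=C(C)C)c2)n1` is the next compound to be measured. Relative to compound 2, the change is methoxymethyl in place of hydrogen on an aromatic carbon. For the measured compounds named here, nothing measured so far speaks to a change of this kind on this ring, so the direction of the step is open. The expectation is a step from compound 2 to compound 3 of a 1.2-fold higher number from compound 2 to compound 3 (0.08 log units; within the scatter), that is, no movement beyond the scatter in either direction. For compound 3 in this assay the estimate is 3000 nM, with a range from 1000 nM to 9000 nM.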

Compound 3, half-maximal cytotoxic concentration: > 25000 nM
Compound 3: no number, only a limit; the forecaster's own chance of this, stated with the estimate: 10%; middle value at least 8.3-fold (0.92 log units) from the limit.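

Compound 3 reads > 25000 nM in this assay, and this value is a limit of the assay, not a number. Methoxymethyl in place of hydrogen on an aromatic carbon gives an at least 10-fold higher number from compound 2 to compound 3 (1.00 log units; beyond the scatter), the first single-place step in the series, and it shows that this position, next to the ring nitrogen and meta to a large group, is not indifferent in this assay, with the change moving the read-out towards more compound tolerated. The step is a bound and not a measured size: the limit of > 25000 nM in this assay, at which 1 of the 3 values shown sits.

On these data alone, whether the shift belongs to the oxygen of the methoxymethyl group or to the added chain as such stays open, and a plain methyl, a hydroxymethyl or an amine on the same aromatic carbon would be needed to separate the two. Also open is whether methoxymethyl would move the number in the same direction on the core of compound 1, since the compounds shown hold this change on one core only.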